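This account rests on a few compounds, and the source may have more. Where it says the series, first, only, none or still open, it means among the compounds named here.

In a functional assay on MCF7 cells (Homo sapiens) for inhibition, read by sulforhodamine B assay (a lower number here means a stronger inhibitor, a higher number a weaker inhibitor), compound 1 `O=C1C=C(Nc2ccc(Br)cc2)C(=O)c2c1nc1n2[C@H]2OC[C@@H](O)[C@H]2OC1` gives 2580 nM and compound 2 `Cc1ccc(NC2=CC(=O)c3nc4n(c3C2=O)[C@H]2OC[C@@H](O)[C@H]2OC4)cc1` gives 1660 nM, which is a 1.6-fold lower number from compound 1 to compound 2 (0.19 log units; within the scatter). Compound 3 `O=C1C=C(N2CCCCC2)C(=O)c2c1nc1n2[C@H]2OC[C@@H](O)[C@H]2OC1` has no number, only a limit, > 8000 nM. Piperidin-1-yl in place of the substituted phenylamino groups gave an at least 3.1-fold higher number from compound 1 to compound 3 (0.49 log units; beyond the scatter) and an at least 4.8-fold higher number from compound 2 to compound 3 (0.68 log units; beyond the scatter). Compound 4 `O=C1C=C(N2CCCC2)C(=O)c2c1nc1n2[C@H]2OC[C@@H](O)[C@H]2OC1` differs from compound 3 by pyrrolidin-1-yl in place of piperidin-1-yl on a double-bonded ring carbon. Neither of those steps swaps one saturated ring for another, so they bear on this change only indirectly, and they leave compound 3 without a measured starting number. No step beyond the scatter is expected in this assay, and the expected step is a number no higher from compound 3 to compound 4 (the limit leaves the size open). Compound 4 is estimated at 8000 nM, with an expected range from 3500 nM to 16000 nM.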

Compound 4, half-maximal inhibitory concentration: > 16000 nM
Compound 4 gave a limit, no number; the forecaster's own chance of this, stated with the estimate: 55%; middle value at least 2.0-fold (0.30 log units) from the limit.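

In this assay compound 4 gives no number, only a limit, > 16000 nM. Pyrrolidin-1-yl in place of the substituted phenylamino groups gave an at least 9.6-fold higher number from compound 2 to compound 4 (0.98 log units; beyond the scatter) and an at least 6.2-fold higher number from compound 1 to compound 4 (0.79 log units; beyond the scatter), so the loss seen with piperidin-1-yl at this double-bonded ring carbon is not confined to that one saturated ring. The step between the two saturated rings cannot be read, since neither end has a number.

Still open, as far as these compounds go, is whether a morpholin-4-yl ring or an open-chain amine such as dimethylamino at this place would give a number rather than a limit.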